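Amide-linked phenyl on the shared core: compound 4 outlook

This account rests on a few compounds, and the source may have more. Where it says the series, first, only, none or still open, it means among the compounds named here.

Compound 3 `COc1cc(-c2nn(-c3cccc(NC(=O)c4ccc(Cl)c(C(F)(F)F)c4)c3)cc2-c2ccncc2)ccc1Cl` carries a 4-chloro-3-(trifluoromethyl)phenyl group on a carbonyl carbon whose other neighbour is an amide-type nitrogen. In a functional assay on NCI-H226 cells (Homo sapiens) for inhibition, read by sulforhodamine B assay, with a stated time of 48 h (a higher number here means that more compound is tolerated, a lower number that less compound is tolerated), compound 3 gives only a limit, > 32500 nM. The two urea analogues of the series also stop at a limit. Compound 1 `COc1cc(-c2nn(-c3cccc(NC(=O)Nc4ccc(Cl)c(Cl)c4)c3)cc2-c2ccncc2)ccc1Cl` gives > 50000 nM in this assay, a limit. Compound 2 `COc1cc(-c2nn(-c3cccc(NC(=O)Nc4cccc(C(F)(F)F)c4)c3)cc2-c2ccncc2)ccc1Cl` gives > 50000 nM in this assay, again a limit. Every one of the three values therefore sits at the limit of > 32500 nM in this assay, at which 1 of the 3 values shown sits, or (the limit of > 50000 nM in this assay, at which 2 of the 3 values shown sit), and no number is known for any member of the series.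

The change to compound 4 `COc1cc(-c2nn(-c3cccc(NC(=O)c4ccccc4)c3)cc2-c2ccncc2)ccc1Cl` is phenyl in place of 4-chloro-3-(trifluoromethyl)phenyl on a carbonyl carbon. The steps already taken, a step that the two limits leave unreadable from compound 1 to compound 2, a step that the two limits leave unreadable from compound 1 to compound 3 and a step that the two limits leave unreadable from compound 2 to compound 3, all connect limits and give no readable size, so none of them shows how the group on the carbonyl carbon moves the read-out. With compound 3 standing at a limit, the working expectation is that compound 4 also stays at or near the top of the assay range, and the expected step that the limit leaves unreadable from compound 3 to compound 4 carries no direction beyond the scatter. For compound 4 the estimate in this assay is 50000 nM, with a range from 20000 nM to 100000 nM.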

Compound 4, concentration lethal to 50% of the cells: > 100000 nM
Compound 4: no number, only a limit; the forecaster's own chance of this, stated with the estimate: 80%; middle value at least 2.0-fold (0.30 log units) away from the limit.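

In this assay compound 4 gives only a limit, > 100000 nM. Compound 1, compound 2 and compound 3 also stop at limits, so the steps from each of them to compound 4 cannot be read. The compounds shown leave open whether changing the group on the carbonyl carbon moves the read-out at all, since none has a number.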